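Methoxy in place of cyano on compound 2

The source may hold more compounds than are shown below. What is called first, only, known or untested is meant among the compounds shown, and "the series" means these compounds.

In an in vitro ADME assay on microsomes from liver (Homo sapiens) for metabolic stability, with a stated time of 15 min (on this read-out higher numbers stand for fast clearance and lower numbers for slow clearance), compound 2 (`COCc1cc(OC)c(-c2cccc3c(N(CC4CCOCC4)CC4CC4)c(C#N)nn23)c(OC)c1`) gives 1100 mL.min-1.g-1 and stands within the scatter of compound 1 (`CCc1nn2c(-c3cc(OC)c(OC)cc3OC)cccc2c1N(CC1CCOCC1)CC1CC1`), which gives 600 mL.min-1.g-1 in the same read-out. Compound 3 (`CCc1nn2c(-c3c(OC)cc(C)cc3OC)cccc2c1N(CC1CCOCC1)CC1CC1`) gives 440 mL.min-1.g-1 and lies lower than compound 2 by a gap beyond the scatter. Compound 4 (`COCc1cc(OC)c(-c2cccc3c(N(CC4CCOCC4)CC4CC4)c(OC)nn23)c(OC)c1`) carries methoxy in place of cyano on an aromatic carbon. Among the measured compounds shown here, no measured pair shows this change alone, so no step beyond the scatter is expected in this assay, in either direction. The estimated step is small (a 1.2-fold lower number from compound 2 to compound 4 (0.09 log units; within the scatter)) and is expected to stay within the scatter. For compound 4 the expected value is 900 mL.min-1.g-1 (range 450 mL.min-1.g-1 to 1800 mL.min-1.g-1).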

Compound 4, intrinsic clearance in microsomes: 760 mL.min-1.g-1
Compound 4: middle estimate off by 1.2-fold (0.07 log units), on the high side; measured number inside the range.
By their numbers in this assay, from the lowest: compounds 3, 1, 4 and 2 (each within the scatter of the next, the first and the last beyond it).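

In this assay, putting methoxy in place of cyano on this aromatic carbon, next to the ring nitrogen, gives a 1.4-fold lower number from compound 2 to compound 4 (0.16 log units; within the scatter) and so stays within the scatter. Among the compounds shown here, this pair is the first to isolate the change at this position, with the rest of compound 2 held constant, and it shows that these two groups cannot be told apart on this read-out. Nothing available explains this outcome. Going by these compounds, whether an amine or a carboxylic acid on this carbon would also stay within the scatter of compound 2 remains open.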